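This account rests on a few compounds, and the source may have more. Where it says the series, first, only, none or still open, it means among the compounds named here.

In an ADME assay on microsomes from liver (Mus musculus) for metabolic stability, read by LC-MS, with a stated time of 10 min, tested at 0.5 uM (a lower number here means that less of the compound is left, a higher number that more of the compound is left), compound 1 `c1ccc2c(c1)CN[C@@H](CN(CC[C@H]1CCCNC1)[C@H]1CCCc3cccnc31)C2` gives 56%, the lowest of the three numbers measured, though only its gap to one other compound lies beyond the scatter. Compound 3 `c1cnc2c(c1)CN[C@H](CN(CCCN1CCNCC1)[C@H]1CCCc3cccnc31)C2` gives 63%, a number within the scatter of compound 1, while compound 2 `c1cnc2c(c1)CCC[C@@H]2N(CCCN1CCNCC1)Cc1nc2ccccc2[nH]1` gives 68%, which lies beyond the scatter on the higher side. Among the measured compounds shown here, the single step measured between two compounds that differ in one place, a number 5 percentage points lower from compound 2 to compound 3 (within the scatter), exchanges a group on a saturated chain carbon bound to an amine nitrogen and stays within the scatter. Compound 4 `NC(=O)N1CCN(CCCN(C[C@H]2Cc3ccccc3CN2)[C@H]2CCCc3cccnc32)CC1` differs from compound 1 at another place: (4-carbamoylpiperazin-1-yl)methyl in place of piperidin-3-yl on a saturated chain carbon, two bonds along the chain from an amine nitrogen. For the measured compounds named here, no measured step touches this group, so nothing shows a direction for it; the only known step, a number 5 percentage points lower from compound 2 to compound 3 (within the scatter), shows a change elsewhere leaving the number roughly where it stood. The step of a number 2 percentage points higher from compound 1 to compound 4 (within the scatter) is therefore expected to stay within the scatter. Compound 4 is estimated at 58%, in a range from 40% to 76%.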

Compound 4, percent of the compound remaining: 42%
Beside the measured number, compound 4's estimate is 16 percentage points above it, within the range that was stated.
By their numbers in this assay, from the lowest: compound 4; then compounds 1, 3 and 2 (each within the scatter of the next, the first and the last beyond it).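

The change of piperidin-3-yl to (4-carbamoylpiperazin-1-yl)methyl matters in this assay: there is a number 14 percentage points lower from compound 1 to compound 4 (beyond the scatter), so less of the compound is left. Among the compounds shown here, this gives the first direction for the place on a saturated chain carbon, two bonds along the chain from an amine nitrogen, and it is the first single change here to move the number beyond the usual scatter. Nothing measured here explains the drop.

The compounds shown do not separate the effect of the carbamoyl group from that of the larger ring and its added methylene link. Going by these compounds, it also remains open how a morpholin-4-ylmethyl group, or an acetyl group in place of the carbamoyl, would fare at this place.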